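Replacing the chloro group of compound 1 with 4-methylpiperazin-1-yl

A few compounds are considered here, and "the series" means these few. Any claim that something is new, unique, unknown or untested is made for them only; others in the source may bear on it.

Compound 1 `N#Cc1c(Cl)nc(SCc2nc3ccccc3[nH]2)nc1-c1ccccc1` carries a chloro group on its shared core. In a functional assay on NCI-H460 cells (Homo sapiens) for cytotoxicity, read by MTT assay, with a stated time of 3 days (on this read-out higher numbers stand for weaker inhibition and lower numbers for stronger inhibition), compound 1 gives 3.28 nM. Its two measured companions are compound 2 `N#Cc1c(NN)nc(SCc2nc3ccccc3[nH]2)nc1-c1ccccc1`, which gives 2.6 nM, and compound 3 `N#Cc1c(Nc2nccs2)nc(SCc2nc3ccccc3[nH]2)nc1-c1ccccc1`, which gives 3.37 nM. All three numbers lie within the usual scatter of one another, so compound 1 cannot be set apart from either: the step of a 1.3-fold lower number from compound 1 to compound 2 (0.10 log units; within the scatter) and the step of a 1.0-fold higher number from compound 1 to compound 3 (0.01 log units; within the scatter) are both small.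

Compound 4 `CN1CCN(c2nc(SCc3nc4ccccc4[nH]3)nc(-c3ccccc3)c2C#N)CC1` differs from compound 1 in one place: 4-methylpiperazin-1-yl in place of chloro on an aromatic carbon. The two measured steps bear directly on this change, since each also swaps the same chloro group for a nitrogen-bearing substituent, and neither moved the number beyond the scatter. The expectation is therefore no step beyond the scatter, in either direction.

Compound 4 is accordingly estimated at 3.5 nM in this assay, within a range of 1.5 nM to 8 nM, the expected step being a 1.1-fold higher number from compound 1 to compound 4 (0.03 log units; within the scatter).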

Compound 4, half-maximal inhibitory concentration: 2.84 nM
For compound 4 the middle estimate is 1.2-fold (0.09 log units) above the measured one; measured number inside the range.
By their numbers in this assay, from the lowest: compounds 2, 4, 1 and 3 (each within the scatter of the next).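

In this assay, this position takes a group of 7 heavy atoms with a six-membered non-aromatic ring in place of a single chlorine, yet the step is only a 1.2-fold lower number from compound 1 to compound 4 (0.06 log units; within the scatter), no larger than those seen with the smaller groups. The new group also cannot be told apart from the two other nitrogen-bearing groups, as a 1.2-fold lower number from compound 3 to compound 4 (0.07 log units; within the scatter) and a 1.1-fold higher number from compound 2 to compound 4 (0.04 log units; within the scatter) both show. Across chloro, aminoamino, (1,3-thiazol-2-yl)amino and 4-methylpiperazin-1-yl, then, no group at this position is set apart from the others.

Still open, from the compounds shown here alone, is whether a methoxy group, a carboxylic acid or a longer carbon chain at this position would also stay within the scatter. Nothing available here explains why these four numbers lie so close together.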